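A few compounds are considered here, and "the series" means these few. Any claim that something is new, unique, unknown or untested is made for them only; others in the source may bear on it.

Compounds measured in an ADME assay on HaCaT cells (Homo sapiens) for antiproliferative activity, read by MTT assay, with a stated time of 48 h; a lower number here means a stronger inhibitor, a higher number a weaker inhibitor:
Compound 1 `COc1cc(N/C=C\C(=O)c2cn(-c3ccccc3)nc2-c2ccccc2)cc(OC)c1OC`: 36200 nM
Compound 2 `O=C(/C=C\Nc1ccc(F)cc1)c1cn(-c2ccccc2)nc1-c1ccc(Cl)cc1`: a limit, > 50000 nM
Compound 3 `O=C(/C=C\Nc1ccc(Cl)cc1)c1cn(-c2ccccc2)nc1-c1ccc(Cl)cc1`: 23400 nM

Compound 1 gives the higher of the two numbers shown in this assay, but its gap to compound 3 lies within the usual scatter, so the two cannot be ranked. Compound 2 reaches only a limit, (the limit of > 50000 nM in this assay, at which 1 of the 3 values shown sits). Going by the values given here, the one measured step, an at least 2.1-fold lower number from compound 2 to compound 3 (0.32 log units; beyond the scatter), concerns a halogen swap on a different ring and says nothing about the change in compound 4 `COc1ccc(-c2nn(-c3ccccc3)cc2C(=O)/C=C\Nc2cc(OC)c(OC)c(OC)c2)cc1`, which is methoxy in place of hydrogen on an aromatic carbon. Among the compounds with values here, with no measured step bearing on it, no step beyond the scatter is expected. Compound 4 is therefore estimated at 30000 nM, in the range 12000 nM to 80000 nM, an expected step of a 1.2-fold lower number from compound 1 to compound 4 (0.08 log units; within the scatter).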

Compound 4, half-maximal inhibitory concentration: > 50000 nM
Compound 4 ended at the assay's limit; the forecaster's own chance of this, stated with the estimate: 25%; middle value at least 1.6-fold (0.22 log units) from the limit.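

Going from phenyl to 4-methoxyphenyl gives an at least 1.3-fold higher number from compound 1 to compound 4 (0.14 log units; that floor lies within the scatter), so in this assay methoxy in this place brings no gain, though the floor of that step does not establish a loss. Compound 4 stands at a limit rather than a number, and compound 2 stands at the same limit: the limit of > 50000 nM in this assay, at which 2 of the 4 values shown sit.

As far as these compounds go, how far compound 4 actually lies from compound 1 stays unknown. Also open, from the compounds shown here alone, is whether an amine, a hydroxyl or a carboxylic acid in place of methoxy on this ring would lower the number.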